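Benzamido for phenoxy on the core of compound 1

This account rests on a few compounds, and the source may have more. Where it says the series, first, only, none or still open, it means among the compounds named here.

Measured so far:
compound 1, `Fc1ccc2c(c1CNc1ncc(Oc3ccccc3)c3nncn13)CCO2`: 3.5
compound 2, `Cc1ncc(-c2cnc(NCc3c(F)ccc4c3CCO4)c3cn[nH]c(=O)c23)n1C`: 1.9
compound 3, `Cc1ncccc1-c1cnc(NCc2c(F)ccc3c2CCO3)c2cn[nH]c(=O)c12`: 3

In a physicochemical assay for lipophilicity, using the shake flask method, in phosphate buffer, measured as octanol-water partition, with a stated time of 30 min, at pH 7.4 (on this read-out higher numbers stand for higher lipophilicity and lower numbers for lower lipophilicity), compound 1 stands highest of the three, with compound 3 nearest and compound 2 furthest. Going by the values given here, the only measured step, a number 1.10 log units higher from compound 2 to compound 3 (beyond the scatter), concerns a different part of the shared core. Compound 4, `O=C(Nc1cnc(NCc2c(F)ccc3c2CCO3)n2cnnc12)c1ccccc1`, differs from compound 1 by benzamido in place of phenoxy on an aromatic carbon. Among the compounds with values here, no measured step bears directly on this change, so the expectation rests on the groups alone: the entering group brings one hydrogen-bond donor where the leaving group had none, and a moderate drop in this assay is therefore expected, a number 0.70 log units lower from compound 1 to compound 4 (beyond the scatter). Compound 4 is estimated at 2.8, expected to lie between 2 and 3.5.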

Compound 4, distribution coefficient: 3
For compound 4 the middle estimate is 0.20 log units below the measured one; measured number inside the range.
By their numbers in this assay, from the lowest: compound 2; then compounds 3 and 4 (each within the scatter of the next); then compound 1.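

In this assay the aromatic carbon para to a large group now has a step of its own, with a number 0.50 log units lower from compound 1 to compound 4 (beyond the scatter) for benzamido in place of phenoxy, a modest change. Going by these compounds alone, the earlier step lay in a different part of the shared core, so this is the first sign that the number responds to the group at this position. No measurement at hand gives a reason for the size of this step. Whether the amide hydrogen or the rest of the benzamido group accounts for it stays open, as does the size of the step for an acetamido group or a plain amine on the same carbon.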